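This account rests on a few compounds, and the source may have more. Where it says the series, first, only, none or still open, it means among the compounds named here.

Compound 1 `CC(=O)N1N=C(c2cc(O)c(O)c([N+](=O)[O-])c2)CC1c1nccs1` — 68200 nM
Compound 2 `CC(=O)N1N=C(c2cc(O)c(O)c([N+](=O)[O-])c2)CC1c1ccc(C#N)cc1` — 83200 nM
Compound 3 `CC(=O)N1N=C(c2cc(O)c(O)c([N+](=O)[O-])c2)CC1c1ccoc1` — 126000 nM

Three compounds share one core and differ only in the group attached to a saturated ring carbon. In an assay on isolated protein for inhibition of Amine oxidase [flavin-containing] B (Homo sapiens), read by fluorescence (on this read-out lower numbers stand for stronger inhibition and higher numbers for weaker inhibition), compound 1 gives the lowest of the three numbers, but the gaps to its neighbours are small: a 1.2-fold higher number from compound 1 to compound 2 (0.09 log units; within the scatter) and a 1.8-fold higher number from compound 1 to compound 3 (0.27 log units; within the scatter), both within the scatter, so none of the three can be set apart from the others on this read-out. The step between the other two, a 1.5-fold higher number from compound 2 to compound 3 (0.18 log units; within the scatter), is likewise within the scatter.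

Compound 4 `CC(=O)N1N=C(c2cc(O)c(O)c([N+](=O)[O-])c2)CC1c1cccc(C#N)c1` has not yet been measured in this assay. It is built from compound 1 by the change (3-cyanophenyl in place of 1,3-thiazol-2-yl on a saturated ring carbon). The closest guide is the step from compound 1 to compound 2, where a cyanophenyl group replaced the same thiazolyl group and gave a 1.2-fold higher number from compound 1 to compound 2 (0.09 log units; within the scatter); the other two steps were also within the scatter. For the measured compounds named here, nothing among the measured compounds suggests that swapping one aromatic group for another at this ring carbon moves the number beyond the scatter, so no change beyond the scatter is expected here either, with the step of a 1.2-fold higher number from compound 1 to compound 4 (0.07 log units; within the scatter) expected for compound 4.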

Compound 4, half-maximal inhibitory concentration: 55400 nM
The estimate for compound 4 lay 1.4-fold (0.16 log units) above the measured number; the range from low to high includes it.
By their numbers in this assay, from the lowest: compounds 4, 1, 2 and 3 (each within the scatter of the next, the first and the last beyond it).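

In this assay, 3-cyanophenyl in place of furan-3-yl gives a 2.3-fold lower number from compound 3 to compound 4 (0.36 log units; beyond the scatter), the only step among these compounds to pass beyond the scatter, so the group on this saturated ring carbon can shift the number, though only modestly. The other two steps, a 1.2-fold lower number from compound 1 to compound 4 (0.09 log units; within the scatter) and a 1.5-fold lower number from compound 2 to compound 4 (0.18 log units; within the scatter), stay within the scatter, so 3-cyanophenyl cannot be told apart from either 1,3-thiazol-2-yl or 4-cyanophenyl, and the position of the nitrile on the phenyl ring shows no readable effect here. No supporting measurement bears on why furan-3-yl and 3-cyanophenyl differ, so the result describes a difference without explaining it.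

From the compounds shown here alone, every group compared at this carbon is an aromatic ring, so it remains open whether a cyclohexyl ring, an amine, a carboxylic acid or a longer alkyl chain would move the number further, and in which direction. Going by these compounds, the acetyl group, the nitro group and the two hydroxyl groups stay the same throughout, so their contribution to the inhibition also remains open.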